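The source may hold more compounds than are shown below. What is called first, only, known or untested is meant among the compounds shown, and "the series" means these compounds.

Measured compounds in a functional assay on the whole organism (strain Wistar) for inhibition, with Rattus norvegicus as the target, read by paw edema, with stated times of 30 min and 120 min, at a dose of 50 mg/kg by the oral route; a higher number here means more inhibition at the dose given (going by the name of the read-out), a lower number less inhibition:

Compound 1 `Fc1ccc(C2=NN(c3ccccc3)C(c3cn(-c4ccccc4)nc3-c3ccc(Cl)c(Cl)c3)C2)cc1` gives 60.2%.
Compound 2 `Clc1ccc(C2=NNC(c3cn(-c4ccccc4)nc3-c3ccc(Cl)c(Cl)c3)C2)cc1` gives 48.4%.
Compound 3 `Clc1ccc(C2=NN(c3ccccc3)C(c3cn(-c4ccccc4)nc3-c3ccc(Cl)c(Cl)c3)C2)cc1` gives 61.7%.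

Compound 4 `Fc1ccc(C2=NNC(c3cn(-c4ccccc4)nc3-c3ccc(Cl)c(Cl)c3)C2)cc1` has not yet been tested in this assay.

The change from compound 3 to compound 1 is fluoro in place of chloro on an aromatic carbon. It gave a number 1.5 percentage points lower from compound 3 to compound 1 (within the scatter). The core of compound 2 differs from that of compound 3 by hydrogen in place of phenyl on an amine nitrogen in a ring, and the step in this assay from compound 2 to compound 3 was a number 13.3 percentage points higher from compound 2 to compound 3 (beyond the scatter). Compound 2 stands lowest of the three measured values, and its steps to compound 1 and compound 3 both lie beyond the scatter.

Compound 4 is related to compound 2 by fluoro in place of chloro on an aromatic carbon. The place of this change is the same, word for word, as in the pair compound 3 and compound 1, so it is the same change made on the other core. Nothing in the data shows how this change behaves on the core of compound 2 itself. The expected step from compound 2 to compound 4 in this assay is a number 1.4 percentage points lower from compound 2 to compound 4 (within the scatter), which rests on the earlier step of a number 1.5 percentage points lower from compound 3 to compound 1 (within the scatter) and on the value of compound 2, 48.4%. On that basis compound 4 is estimated at 47% in this assay, with a likely range from 38% to 56%.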

Compound 4, a percentage reported as inhibition, in the whole organism at one dose (the size of the read-out at that dose, not a potency): 46.1%
Compound 4: the middle estimate sits 0.9 percentage points above what was measured; the range from low to high includes it.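

In the series, 4-chlorophenyl to 4-fluorophenyl in this assay gave a number 2.3 percentage points lower from compound 2 to compound 4 (within the scatter) and so stayed as small on the core of compound 2 as on the core of compound 3: the same change on two cores in this assay, a number 1.5 percentage points lower (within the scatter) from compound 3 to compound 1 and a number 2.3 percentage points lower (within the scatter) from compound 2 to compound 4, 0.8 percentage points apart, within the scatter of two such steps

Hydrogen in place of phenyl on the amine nitrogen in a ring gave a number 14.1 percentage points lower from compound 1 to compound 4 (beyond the scatter) and this step also read the same with either aromatic substituent: the same change on two cores in this assay, a number 13.3 percentage points higher (beyond the scatter) from compound 2 to compound 3 and a number 14.1 percentage points higher (beyond the scatter) from compound 4 to compound 1, 0.8 percentage points apart, within the scatter of two such steps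

The two changes therefore combine without visible interaction across these compounds, but this rests on one closed set of compounds, with both fluoro-for-chloro steps within the scatter, and does not show that the change would stay small on any other core.

Open, going by these compounds, is whether a group other than fluoro or chloro at that place, such as methoxy, nitrile or a carboxylic acid, would move the number. On these data alone, on the ring nitrogen only hydrogen and phenyl appear, so an acetyl group or a short alkyl chain there also remains open.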